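This account rests on a few compounds, and the source may have more. Where it says the series, first, only, none or still open, it means among the compounds named here.

Of the compounds shown here, two built on a shared core have been tested in a functional assay on PC-3 cells (Homo sapiens) for antiproliferative activity, read by MTT assay; on this read-out lower numbers stand for stronger inhibition and higher numbers for weaker inhibition. Compound 1 `Cn1c(=O)c(=O)n(C2CCCC2)c2nc(N/N=C/c3ccc(F)c(Cl)c3)ncc21` carries a 3-chloro-4-fluorophenyl group on a carbon with a double bond to nitrogen, and in this assay compound 1 gives 8550 nM. Compound 2 `Cc1ccc(/C=N/Nc2ncc3c(n2)n(C2CCCC2)c(=O)c(=O)n3C)cc1C` carries a 3,4-dimethylphenyl group on that same carbon, and in this assay compound 2 gives 39000 nM. The step of a 4.6-fold higher number from compound 1 to compound 2 (0.66 log units; beyond the scatter) is the only measured one, and it leaves compound 2 with the highest of the two numbers, so compound 2 is the weaker inhibitor of the pair. Compound 3 `COc1ccc(/C=N/Nc2ncc3c(n2)n(C2CCCC2)c(=O)c(=O)n3C)c(OC)c1` has not yet been measured. It differs from compound 2 in a single place: 2,4-dimethoxyphenyl in place of 3,4-dimethylphenyl on a carbon with a double bond to nitrogen. Among the compounds with values here, the one step that bears on this change is a 4.6-fold higher number from compound 1 to compound 2 (0.66 log units; beyond the scatter); it shows that exchanging the group on this carbon can shift the number well beyond the scatter, yet it involves neither of the two groups in question, so its direction cannot simply be carried over. For compound 3 the number in this assay is therefore expected to sit close to that of compound 2, giving an expected step of a 1.6-fold lower number from compound 2 to compound 3 (0.19 log units; within the scatter). The estimate for compound 3 is 25000 nM, with a range from 8000 nM to 80000 nM.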

Compound 3, half-maximal inhibitory concentration: > 100000 nM
Compound 3 was reported as a limit (the forecaster's own chance of this, stated with the estimate: 15%); middle value at least 4.0-fold (0.60 log units) from the limit.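

Compound 3 is reported only as a limit of the assay, not as a number: the limit of > 100000 nM in this assay, at which 1 of the 3 values shown sits. In this assay, putting 2,4-dimethoxyphenyl in place of 3,4-dimethylphenyl gives an at least 2.5-fold higher number from compound 2 to compound 3 (0.40 log units; beyond the scatter), and putting it in place of 3-chloro-4-fluorophenyl gives an at least 11-fold higher number from compound 1 to compound 3 (1.06 log units; beyond the scatter). Within the data shown here, the earlier pair showed only that this carbon with a double bond to nitrogen tolerates a change of group with a shift in the number, whereas these steps show that the shift can be large, and that 2,4-dimethoxyphenyl, the only one of the three groups with oxygen atoms, gives the weakest inhibitor of the set.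

The compounds shown do not separate the effect of the methoxy groups themselves from the effect of where they sit on the ring, since the two dimethoxy positions change together with everything else about the group. As far as these compounds go, how a phenyl group carrying a single methoxy, an amine or a carboxylic acid would behave on this carbon also stays open.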